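The compounds below may be only part of what the source reports. "The series", "measured", "known", "first", "only" and "open" are said of these compounds alone.

Measured so far in an ADME assay on HEK-293T cells (Homo sapiens) for inhibition, read by CCK-8 assay, with a stated time of 48 h, tested at 20 uM; a lower number here means less inhibition of growth, a higher number more inhibition of growth at the concentration tested:
- compound 1 (`Cc1ccc(Cc2nnc(NC(=O)/C(C#N)=C/c3ccccc3OS(=O)(=O)c3ccc(C)cc3)s2)cc1`) gives 22%
- compound 2 (`COc1ccc(S(=O)(=O)Oc2ccccc2/C=C(\C#N)C(=O)Nc2nnc(Cc3ccc(C)cc3)s2)cc1`) gives 28%

Among the compounds with values here, these are the only two numbers available, and compound 2 stands level with compound 1 once the usual scatter of repeated measurements is allowed for. Within the data shown here, the single measured step is a number 6 percentage points higher from compound 1 to compound 2 (within the scatter), with methoxy in place of methyl on an aromatic carbon.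

The next compound, compound 3 (`Cc1ccc(Cc2nnc(NC(=O)/C(C#N)=C/c3ccccc3OS(=O)(=O)c3ccc(Cl)cc3)s2)cc1`), is altered at that same place on the ring. Its difference from compound 2 is chloro in place of methoxy on an aromatic carbon. In plain words, 4-methoxyphenyl becomes 4-chlorophenyl, with chloro in place of methoxy on an aromatic carbon.

Among the measured compounds shown here, only the step from compound 1 to compound 2 bears on this, and it stayed within the scatter. Chloro itself has no measurement yet, so the evidence is thin. No step beyond the scatter is expected in this assay, in either direction. The expected step is a number 2 percentage points lower from compound 2 to compound 3 (within the scatter). For compound 3 the estimated value is 26% with an expected range from 13% to 40%.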

Compound 3, percent growth inhibition at one concentration: 8%
The estimate for compound 3 lay 18 percentage points above the measured number; measured number outside the range, below it.
By their numbers in this assay, from the lowest: compound 3; then compounds 1 and 2 (each within the scatter of the next).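

The earlier pair suggested that this position, on the six-membered aromatic ring of carbon only and para to a large group, might tolerate a change without any readable effect in this assay on these cells. Chloro shows that the group here can matter: with chloro in place of methoxy, the result is a number 20 percentage points lower from compound 2 to compound 3 (beyond the scatter) and with chloro in place of methyl, it is a number 14 percentage points lower from compound 1 to compound 3 (beyond the scatter) so both earlier compounds separate from compound 3 by more than the usual scatter, while methyl and methoxy remain level with each other. Nothing available explains why chloro behaves differently from the other two groups, so the result describes what happens and gives no cause.

Within the data shown here, with only three groups at this position, it remains open whether the lower number belongs to chloro alone or would also appear with fluoro, bromo or trifluoromethyl. An amine or a carboxylic acid at the same place, or a longer chain such as ethoxy or butoxy in place of methoxy, would show how far the response extends across different kinds of group.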